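Swapping Cyclopentyl for Benzyl on a Shared Core

A few compounds are considered here, and "the series" means these few. Any claim that something is new, unique, unknown or untested is made for them only; others in the source may bear on it.

Of the compounds shown here, three have been measured in a functional assay on HepG2 cells (Homo sapiens) for antiproliferative activity, read by CCK-8 assay, with a stated time of 72 h, tested at 2 uM; a lower number here means a weaker effect, a higher number a stronger effect of the compound at the concentration tested. Compound 1 `COC(CCn1cnc2c(NCc3ccc(C(=O)Nc4ccccc4N)cc3)nc(Cl)nc21)OC` carries a 3,3-dimethoxypropyl group on an aromatic nitrogen of the shared core, and in this assay compound 1 gives 8.52%. Compound 2 `CCC(C)n1cnc2c(NCc3ccc(C(=O)Nc4ccccc4N)cc3)nc(Cl)nc21` carries sec-butyl at the same place, and compound 2 gives 45%. Compound 3 `Nc1ccccc1NC(=O)c1ccc(CNc2nc(Cl)nc3c2ncn3C2CCCC2)cc1` carries cyclopentyl there, and compound 3 gives 54.7%, the highest of the three numbers. Its gap to compound 2 is within the scatter (a number 9.7 percentage points higher from compound 2 to compound 3 (within the scatter)), while both gaps to compound 1 are beyond it (a number 36.5 percentage points higher from compound 1 to compound 2 (beyond the scatter); a number 46.2 percentage points higher from compound 1 to compound 3 (beyond the scatter)).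

Compound 4 `Nc1ccccc1NC(=O)c1ccc(CNc2nc(Cl)nc3c2ncn3Cc2ccccc2)cc1` differs from compound 3 in one place: benzyl in place of cyclopentyl on an aromatic nitrogen. Within the data shown here, no measured step puts an aromatic ring at this position, so the only guides are the small step from sec-butyl to cyclopentyl and the large rise from 3,3-dimethoxypropyl to either of them. A step of a number 4.7 percentage points lower from compound 3 to compound 4 (within the scatter) is therefore expected, not clearly up or down beyond the scatter. Compound 4 is estimated at 50%, between 25% and 75% in this assay.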

Compound 4, a percentage reported as inhibition, at one concentration (the size of the read-out at that concentration, not a potency): 5.01%
Compound 4: middle estimate off by 45 percentage points, on the high side; the measured number lies below the stated range.
By their numbers in this assay, from the lowest: compounds 4 and 1 (each within the scatter of the next); then compounds 2 and 3 (each within the scatter of the next).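

In this assay, among these compounds, the earlier compounds showed only that sec-butyl and cyclopentyl on this aromatic nitrogen stay within the scatter of each other, whereas benzyl gives a number 49.7 percentage points lower from compound 3 to compound 4 (beyond the scatter) and a number 40 percentage points lower from compound 2 to compound 4 (beyond the scatter) and so marks a sharp limit on what this position accepts. Neither cyclopentyl nor benzyl has any hydrogen-bond donors or acceptors or a net charge, so a large loss here can occur without any change in those counts. Benzyl also gives a number 3.5 percentage points lower from compound 1 to compound 4 (within the scatter) and so joins the 3,3-dimethoxypropyl group at the low end, leaving sec-butyl and cyclopentyl as the two groups of these four with the higher numbers.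

Nothing available explains why benzyl behaves so differently from cyclopentyl. From the compounds shown here alone, it remains open whether cyclohexyl, phenyl placed directly on the ring nitrogen, or a benzyl ring carrying an amine would keep the number up or lose it.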